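This account rests on a few compounds, and the source may have more. Where it says the series, first, only, none or still open, it means among the compounds named here.

In a functional assay on HL-60 cells (Homo sapiens) for antiproliferative activity, with a stated time of 72 h (a higher number here means a weaker inhibitor, a lower number a stronger inhibitor), the measured compounds are:
Compound 1 `Cc1cccc(CNc2ncnc3c2ncn3[C@@H]2O[C@H](CO)[C@@H](O)[C@H]2O)c1` gives 6400 nM
Compound 2 `OC[C@H]1O[C@@H](n2cnc3c(NCc4ccc(F)c(Cl)c4)ncnc32)[C@H](O)[C@@H]1O` gives 3500 nM

Among the measured compounds shown here, compound 2 lies within the scatter of compound 1, the only other measured compound, so the two values set no order between them. The unmeasured compound 3 `Cc1cccc(CNc2ncnc3c2ncn3[C@@H]2O[C@H](CO)[C@@H](O)[C@H]2O)c1O` differs from compound 2 in one place, on a saturated chain carbon bound to a nitrogen on an aromatic ring. The change is 2-hydroxy-3-methylphenyl in place of 3-chloro-4-fluorophenyl on a saturated chain carbon bound to a nitrogen on an aromatic ring and it puts 2-hydroxy-3-methylphenyl in place of 3-chloro-4-fluorophenyl. For the measured compounds named here, one measured step bears on this, the exchange at that same place of 3-methylphenyl for 3-chloro-4-fluorophenyl, which gave a 1.8-fold lower number from compound 1 to compound 2 (0.26 log units; within the scatter) and stays within the scatter. Going by the values given here, no measured compound carries 2-hydroxy-3-methylphenyl, so this single step is a thin guide and the range must stay wide. No step beyond the scatter is expected, in either direction. The estimated change is a 1.2-fold lower number from compound 2 to compound 3 (0.07 log units; within the scatter) and no more is expected from the data at hand. For compound 3 the estimated value is 3000 nM with 900 nM to 10000 nM as the expected range.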

Compound 3, half-maximal inhibitory concentration: 15000 nM
Compound 3: middle estimate off by 5.0-fold (0.70 log units), on the low side, and the stated range ends below it.
By their numbers in this assay, from the lowest: compounds 2 and 1 (each within the scatter of the next); then compound 3.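

In this assay, the aryl group on a saturated chain carbon bound to a nitrogen on an aromatic ring can move the number beyond the scatter: replacing 3-chloro-4-fluorophenyl with 2-hydroxy-3-methylphenyl gives a 4.3-fold higher number from compound 2 to compound 3 (0.63 log units; beyond the scatter) and so a weaker inhibitor, whereas the earlier exchange at this place stayed within the scatter. The most direct comparison is the addition of a hydroxy in place of hydrogen on an aromatic carbon, which gives a 2.3-fold higher number from compound 1 to compound 3 (0.37 log units; beyond the scatter) while the methyl and the rest of the molecule stay the same, so this single added group is enough for a modest step towards weaker inhibition. No supporting measurement is available to say why the number rises.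

The compounds shown leave open whether a methoxy group or an amino group in place of that hydroxy would give a similar rise, and whether a hydroxy would have the same effect on the 3-chloro-4-fluorophenyl ring of compound 2. Among the compounds shown here, with only one hydroxy-bearing compound among the three, no wider trend at this position can be stated.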